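The source may report more compounds than this note shows. Statements on the series, on what has been measured and on what is new or still open speak of the compounds shown alone.

Going by the values given here, of the two compounds measured so far, compound 2 `CC(C)N1CCC(c2ccc3c(c2)oc(=O)n3C(=O)NCCCCc2ccccc2)CC1` has the lower number: in an assay on HEK293 cells for inhibition of acid ceramidase (Homo sapiens), read by fluorescence, with stated times of 10 min and 3 h (a lower number here means a stronger inhibitor, a higher number a weaker inhibitor), compound 2 gives 94 nM, whereas compound 1 `CC(C)N1CCN(c2ccc3c(c2)oc(=O)n3C(=O)NCCCCc2ccccc2)CC1` gives 211 nM in this assay. Among the compounds with values here, the single measured step is a 2.2-fold lower number from compound 1 to compound 2 (0.35 log units; beyond the scatter). Compound 3 `CN1CCC(c2ccc3c(c2)oc(=O)n3C(=O)NCCCCc2ccccc2)CC1=O` has not yet been measured; its change from compound 2 is 1-methyl-2-oxopiperidin-4-yl in place of 1-isopropylpiperidin-4-yl on an aromatic carbon. Within the data shown here, that measured step exchanged 4-isopropylpiperazin-1-yl for 1-isopropylpiperidin-4-yl at the same place, so it bears on compound 3 only loosely; no measured compound here has the isopropyl group replaced by methyl or carries a ring carbonyl. Among the measured compounds shown here, with no direct precedent, the expected outcome for compound 3 is a small rise in the number, a 2.7-fold higher number from compound 2 to compound 3 (0.42 log units; beyond the scatter), which may still sit within the scatter. Compound 3 is therefore estimated at 250 nM in this assay, with a range from 80 nM to 800 nM.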

Compound 3, half-maximal inhibitory concentration: 105 nM
Beside the measured number, compound 3's estimate is 2.4-fold (0.38 log units) above it; the measured number falls inside the stated range.
By their numbers in this assay, from the lowest: compounds 2, 3 and 1 (each within the scatter of the next, the first and the last beyond it).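

In this assay, the step of a 1.1-fold higher number from compound 2 to compound 3 (0.05 log units; within the scatter) shows that, on this aromatic carbon, 1-methyl-2-oxopiperidin-4-yl gives a number that cannot be told apart from that of 1-isopropylpiperidin-4-yl, even though the new group has a methyl in place of the isopropyl and adds a ring carbonyl. The step of a 2.0-fold lower number from compound 1 to compound 3 (0.30 log units; within the scatter) also lies within the scatter, so compound 3 cannot be separated from compound 1 either, although compound 1 and compound 2 are separated beyond it. No supporting measurement is available to explain these results.

On these data alone, the change altered two features at once, so the separate effects of the methyl and the carbonyl remain open; 1-methylpiperidin-4-yl and 1-isopropyl-2-oxopiperidin-4-yl would separate them. Also open, as far as these compounds go, is how a group without a ring at this place, such as a simple amine or a carboxylic acid, would read.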